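Shared core series: chloro to ethyl on the aryl ring

The source may hold more compounds than are shown below. What is called first, only, known or untested is meant among the compounds shown, and "the series" means these compounds.

The compounds share one core and differ only in the group attached to the carbonyl carbon. Compound 1 `O=C(/C=C/c1ccc2c(c1)B(O)OC2)c1ccccc1` in a functional assay on HCT-116 cells (Homo sapiens) for cytotoxicity, read by MTT assay, with a stated time of 48 h (a higher number here means a weaker inhibitor, a lower number a stronger inhibitor), gives 6100 nM. Compound 2 `O=C(/C=C/c1ccc2c(c1)B(O)OC2)c1cccs1` gives 14200 nM in this assay. Compound 3 `O=C(/C=C/c1ccc2c(c1)B(O)OC2)c1ccc(Cl)cc1` gives 9300 nM in this assay, which places compound 3 second highest of the three numbers, with compound 1 nearest and compound 2 furthest, both gaps within the scatter. The measured steps are a 2.3-fold higher number from compound 1 to compound 2 (0.37 log units; beyond the scatter), a 1.5-fold higher number from compound 1 to compound 3 (0.18 log units; within the scatter) and a 1.5-fold lower number from compound 2 to compound 3 (0.18 log units; within the scatter).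

Compound 4 `CCc1ccc(C(=O)/C=C/c2ccc3c(c2)B(O)OC3)cc1` differs from compound 3 by ethyl in place of chloro on an aromatic carbon. The step that bears most directly on it is a 1.5-fold higher number from compound 1 to compound 3 (0.18 log units; within the scatter), where placing a chloro on the same aromatic carbon left the number within the scatter; a 1.5-fold lower number from compound 2 to compound 3 (0.18 log units; within the scatter) was likewise within the scatter. Replacing that chloro by ethyl is therefore expected to give no step beyond the scatter in this assay. The estimate for compound 4 is 8000 nM, with a range from 4000 nM to 16000 nM. This corresponds to an expected step of a 1.2-fold lower number from compound 3 to compound 4 (0.07 log units; within the scatter).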

Compound 4, half-maximal inhibitory concentration: 10900 nM
Beside the measured number, compound 4's estimate is 1.4-fold (0.13 log units) below it, within the range that was stated.
By their numbers in this assay, from the lowest: compounds 1, 3, 4 and 2 (each within the scatter of the next, the first and the last beyond it).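

In this assay, ethyl in place of chloro on an aromatic carbon, para to a large group, gives a 1.2-fold higher number from compound 3 to compound 4 (0.07 log units; within the scatter) and so leaves the number unresolved between these two substituents. Ethyl in place of hydrogen at the same carbon gives a 1.8-fold higher number from compound 1 to compound 4 (0.25 log units; within the scatter) and, like the chloro of compound 3, stays within the scatter of the unsubstituted compound 1, so two different substituents at this position now show no step beyond the scatter. No measurement available here speaks to why these groups read alike.

On these data alone, whether an amine, a carboxylic acid or a chain longer than ethyl at this carbon would move the number beyond the scatter stays open. Among the compounds shown, only the change from phenyl to thiophen-2-yl on the carbonyl carbon gives a step beyond the scatter, and how far other groups in that place would shift the number also stays open.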